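Swapping a Five-Membered Heteroaryl Group on a Shared Core

This account rests on a few compounds, and the source may have more. Where it says the series, first, only, none or still open, it means among the compounds named here.

Four compounds share a core that carries an amino group and a pendant five-membered heteroaryl ring. Compound 1 `Cc1noc(C)c1-c1cnc(N)c(Oc2ccc(C(=O)Nc3cccc(Cl)c3)cc2)n1` and compound 2 `Cn1cc(-c2cnc(N)c(Oc3ccc(C(=O)Nc4cccc(Cl)c4)cc3)n2)cn1` differ in one place: 1-methyl-1H-pyrazol-4-yl in place of 3,5-dimethyl-1,2-oxazol-4-yl on an aromatic carbon. Compound 3 `Cc1noc(C)c1-c1cnc(N)c(Sc2ccc(C(=O)Nc3ccc(Cl)cc3)cc2)n1` and compound 4 `Cn1cc(-c2cnc(N)c(Sc3ccc(C(=O)Nc4ccc(Cl)cc4)cc3)n2)cn1` differ by the same change, (1-methyl-1H-pyrazol-4-yl in place of 3,5-dimethyl-1,2-oxazol-4-yl on an aromatic carbon). How the core of compound 1 differs from the core of compound 3 is not broken down here.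

In a functional assay on U-87MG ATCC cells for inhibition, with U-87 MG (Homo sapiens) as the target, read by MTT assay, with a stated time of 72 h (on this read-out higher numbers stand for weaker inhibition and lower numbers for stronger inhibition), compound 1 gives 11500 nM. In this assay compound 2 gives 21700 nM. The step of a 1.9-fold higher number from compound 1 to compound 2 (0.28 log units; within the scatter) is therefore small. For compound 3 this assay reports only a limit, > 100000 nM, and not a number. That value sits at the limit of > 100000 nM in this assay, at which 1 of the 3 values shown sits.

Because the earlier step was a 1.9-fold higher number from compound 1 to compound 2 (0.28 log units; within the scatter), compound 4 is expected to make a step that the limit leaves unreadable from compound 3 to compound 4. Compound 4 is accordingly estimated at 150000 nM in this assay, with an expected range from 50000 nM to 500000 nM, and most probably it will again be reported only as a limit.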

Compound 4, half-maximal inhibitory concentration: > 100000 nM
Compound 4 ended at the assay's limit (the forecaster's own chance of this, stated with the estimate: 80%); the middle value is on the limit's open side.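

No step can be read from compound 3 to compound 4, because each of the two is reported only as a limit and not as a number: the limit of > 100000 nM in this assay, at which 2 of the 4 values shown sit.

The compounds shown leave open whether 1-methyl-1H-pyrazol-4-yl in place of 3,5-dimethyl-1,2-oxazol-4-yl changes the read-out on the core of compound 3 as little as it does on the core of compound 1.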